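A few compounds are considered here, and "the series" means these few. Any claim that something is new, unique, unknown or untested is made for them only; others in the source may bear on it.

Measured compounds:
- compound 1 `Clc1ccc(Cn2cc(C3CC(c4ccncc4)=NO3)c3ccccc32)cc1`: 10200 nM
- compound 2 `COc1ccc2c(C3CC(c4ccncc4)=NO3)c[nH]c2c1`: 4160 nM

In a functional assay on HEK293 cells (Homo sapiens) for inhibition, read by MTT assay, with a stated time of 48 h (on this read-out higher numbers stand for weaker inhibition and lower numbers for stronger inhibition), compound 2 gives the lower of the two numbers, and compound 1 sits at a higher number, a gap that lies beyond the scatter. Compound 3 `COc1ccc2c(C3CC(c4ccncc4)=NO3)cn(Cc3ccc(Cl)cc3)c2c1` is derived from compound 2 by one change: 4-chlorobenzyl in place of hydrogen on an aromatic nitrogen. For the measured compounds named here, no step between measured compounds covers this change on its own. Judged only from what compound 1 and compound 2 show, a modest rise in the number is expected, the step of a 1.7-fold higher number from compound 2 to compound 3 (0.23 log units; within the scatter) being small. Compound 3 is therefore estimated at 7000 nM in this assay, in the range 2500 nM to 20000 nM.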

Compound 3, half-maximal inhibitory concentration: 37200 nM
For compound 3 the middle estimate is 5.3-fold (0.73 log units) below the measured one, and the stated range ends below it.
By their numbers in this assay, from the lowest: compound 2; then compound 1; then compound 3.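

In this assay, the aromatic nitrogen proves sensitive to substitution: 4-chlorobenzyl in place of hydrogen gives an 8.9-fold higher number from compound 2 to compound 3 (0.95 log units; beyond the scatter) and thus weaker inhibition. With 4-chlorobenzyl on that nitrogen, methoxy in place of hydrogen on an aromatic carbon does not restore inhibition, giving a 3.6-fold higher number from compound 1 to compound 3 (0.56 log units; beyond the scatter) instead. No available evidence accounts for either step.

Going by these compounds, whether methyl or a longer chain ending in an amine on the same nitrogen would raise the number as well remains open. So does whether a hydroxyl group in place of the methoxy of compound 3 would change it.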